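A few compounds are considered here, and "the series" means these few. Any claim that something is new, unique, unknown or untested is made for them only; others in the source may bear on it.

Measured so far in a functional assay on MOLT-4 cells (Homo sapiens); on this read-out higher numbers stand for weaker inhibition and lower numbers for stronger inhibition:

- compound 1, `Cc1ccc(/C=C/C(=O)Oc2ccc(/C=C3\CCCCC3=O)cc2)cc1`: 156000 nM
- compound 2, `COc1ccc(/C=C/C(=O)Oc2ccc(/C=C3\CCCCC3=O)cc2)cc1`: 2060 nM
- compound 3, `Cc1ccc(C(=O)Oc2ccc(/C=C3\CCCCC3=O)cc2)cc1`: 25600 nM

Compounds 1 and 2 share one core and differ only by methoxy in place of methyl on an aromatic carbon; this change gave a 76-fold lower number from compound 1 to compound 2 (1.88 log units; beyond the scatter). Compound 3 carries a different core, and the difference between the two cores is not broken down here; its value stands between those of compound 1 and compound 2. Compound 4, `COc1ccc(C(=O)Oc2ccc(/C=C3\CCCCC3=O)cc2)cc1`, is not yet measured and differs from compound 3 by methoxy in place of methyl on an aromatic carbon, on an aromatic carbon of a six-membered aromatic ring of carbon only, para to a large group. The place of the change reads the same as for compound 1 and compound 2, so it is the same change, now made on the core of compound 3. Among the measured compounds shown here, since the only precedent in this assay is the step from compound 1 to compound 2, and the core is not the same, a step in the same direction but of more moderate size is expected from compound 3 to compound 4, namely a 10-fold lower number from compound 3 to compound 4 (1.01 log units; beyond the scatter). Compound 4 is estimated at 2500 nM, with a range from 300 nM to 12000 nM.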

Compound 4, half-maximal inhibitory concentration: 34000 nM
Estimate against measurement, compound 4: 14-fold (1.13 log units) below, and the stated range ends below it.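

In this assay, among the compounds shown here, methoxy in place of methyl on an aromatic carbon did not carry over from one core to the other: the large step seen on the core of compound 1 has no counterpart on the core of compound 3, where the same change gave a 1.3-fold higher number from compound 3 to compound 4 (0.12 log units; within the scatter). The two steps lie further apart than the scatter of two such steps allows: the same change on two cores in this assay, a 76-fold lower number (1.88 log units; beyond the scatter) from compound 1 to compound 2 and a 1.3-fold higher number (0.12 log units; within the scatter) from compound 3 to compound 4, 100-fold (2.00 log units) apart, beyond the scatter of two such steps. This shows that, in these two pairs, the step measured on one core did not predict the step on the other, but two pairs do not show which difference between the cores is responsible, nor whether the same would hold for any other change.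

The compounds shown leave open how an amine, a carboxylic acid or a longer chain such as ethoxy would read out in the place of the methyl or methoxy on either core. They also leave open whether the large step belongs to methoxy alone or would appear with other groups on the core of compound 1.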